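Swapping 2-chlorobenzyl for 4-methylbenzyl: compound 2 to compound 3

The compounds below may be only part of what the source reports. "The series", "measured", "known", "first", "only" and "open" are said of these compounds alone.

- Compound 1 `O=C1N/C(=N\Cc2ccc(C(F)(F)F)cc2)S/C1=C1/CCNC(=O)c2[nH]ccc21`: > 100000 nM
- Compound 2 `O=C1N/C(=N\Cc2ccccc2Cl)S/C1=C1/CCNC(=O)c2[nH]ccc21`: 21200 nM

Among the measured compounds shown here, in a functional assay on MCF7 cells (Homo sapiens) for inhibition, read by MTT assay, with a stated time of 48 h (a lower number here means a stronger inhibitor, a higher number a weaker inhibitor), compound 2 gives 21200 nM, the only actual number so far. The entry for compound 1 is a limit of the assay, not a number.

Compound 3 `Cc1ccc(C/N=C2\NC(=O)/C(=C3\CCNC(=O)c4[nH]ccc43)S2)cc1` has 4-methylphenyl in place of 2-chlorophenyl on a saturated chain carbon bound to a double-bonded nitrogen. For the measured compounds named here, no step between measured compounds is available as a guide. A modest weakening in this assay is therefore expected, with the estimated change a 1.7-fold higher number from compound 2 to compound 3 (0.22 log units; within the scatter). Compound 3 is estimated at 35000 nM, with an expected range from 12000 nM to 100000 nM.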

Compound 3, half-maximal inhibitory concentration: 8150 nM
Compound 3: middle estimate off by 4.3-fold (0.63 log units), on the high side; measured number outside the range, below it.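

In this assay, the group on the saturated chain carbon bound to a double-bonded nitrogen can shift the number beyond the scatter: 4-methylbenzyl in place of 2-chlorobenzyl gives a 2.6-fold lower number from compound 2 to compound 3 (0.42 log units; beyond the scatter). With only the aromatic substituent changed, methyl in place of trifluoromethyl gives an at least 12-fold lower number from compound 1 to compound 3 (1.08 log units; beyond the scatter). The entry for compound 1 is a limit, so that step is a bound: the limit of > 100000 nM in this assay, at which 1 of the 3 values shown sits. The step from 2-chlorobenzyl changes both the substituent and its place on the ring, so the two contributions remain unseparated. Going by these compounds, how plain benzyl, 4-chlorobenzyl or 4-methoxybenzyl would read here remains open.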